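The source may hold more compounds than are shown below. What is called first, only, known or untested is meant among the compounds shown, and "the series" means these compounds.

In a functional assay on CNE-2 cells (Homo sapiens) for antiproliferative activity, read by sulforhodamine B assay, with a stated time of 48 h (on this read-out higher numbers stand for weaker inhibition and lower numbers for stronger inhibition), compound 3 `COc1ccc(/C=C/C(=O)c2ccccc2-c2ccc(F)cc2)cc1OC` gives 81 nM. Compound 2 `COc1ccc(/C=C/C(=O)c2ccccc2-c2ccc(F)cc2)cc1` gives 53 nM, which lies within the scatter of compound 3, while compound 1 `COc1ccc(/C=C/C(=O)c2ccccc2-c2ccc(OC)c(OC)c2)cc1OC` stands far off at 2500 nM. Compound 3 therefore belongs with compound 2 at the low end of the three numbers.

Compound 4 `COc1cc(/C=C/C(=O)c2ccccc2-c2ccc(F)cc2)ccc1O` differs from compound 3 by hydrogen in place of methyl on an oxygen on an aromatic ring, or methoxy to hydroxy. Within the data shown here, no measured step makes this exact change. The closest is a 1.5-fold higher number from compound 2 to compound 3 (0.18 log units; within the scatter), where a methoxy is added on the same ring and the number stays within the scatter. The other measured step, a 31-fold lower number from compound 1 to compound 3 (1.49 log units; beyond the scatter), is large, but it is a change elsewhere in the molecule and says little about this one. A methoxy on this ring has so far mattered little, but a free hydroxy has not been tested in this series, so some uncertainty remains, leaning towards weaker inhibition. For compound 4 the expected change is a 1.5-fold higher number from compound 3 to compound 4 (0.17 log units; within the scatter), and no step beyond the scatter is anticipated. Compound 4 is estimated at 120 nM, with an expected range from 40 nM to 400 nM.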

Compound 4, half-maximal inhibitory concentration: 2500 nM
Compound 4: middle estimate off by 21-fold (1.32 log units), on the low side; the measured number lies above the stated range.
By their numbers in this assay, from the lowest: compounds 2 and 3 (each within the scatter of the next); then compounds 1 and 4 (each within the scatter of the next).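

In this assay, the step of a 31-fold higher number from compound 3 to compound 4 (1.49 log units; beyond the scatter) is large and shows that the methyl on this oxygen on an aromatic ring matters a great deal: methoxy to hydroxy at this place goes with much weaker inhibition. The earlier step of a 1.5-fold higher number from compound 2 to compound 3 (0.18 log units; within the scatter) had made this ring look tolerant, but that step added a different methoxy and left this oxygen and its methyl in place, so the tolerance it showed does not extend to this methyl, and the ring cannot be treated as uniformly forgiving. Nothing available gives a measured property or other independent information that would explain the size of this change.

The compounds shown leave open whether the methyl is the specific requirement or whether another group on the same oxygen, such as an ethyl or a longer chain, would keep the number close to that of compound 3, and whether an amine in place of the hydroxy would behave like the hydroxy or the methoxy. They also leave open whether methoxy to hydroxy at this place has a step of similar size when the 4-fluorophenyl is replaced by the 3,4-dimethoxyphenyl.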